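Swapping the ring on the sulfonyl: quinolin-7-yl to isoquinolin-3-yl

The compounds below may be only part of what the source reports. "The series", "measured", "known", "first", "only" and "open" are said of these compounds alone.

Measured compounds:
compound 1, `O=S(=O)(c1cc2ccccc2cn1)n1cc(C2=CCNCC2)c2ccccc21`, 12 nM
compound 2, `COc1ccc2c(c1)c(C1=CCNCC1)cn2S(=O)(=O)c1ccc2cccnc2c1`, 2 nM

Both compounds were tested in an assay on HEK293 cells for displacement of a labelled ligand from 5-hydroxytryptamine receptor 6 (Homo sapiens), read by scintillation counting; on this read-out higher numbers stand for weaker inhibition and lower numbers for stronger inhibition. Compound 2 gives the lowest of the two numbers, with 2 nM, and its nearest neighbour is compound 1, whose value of 12 nM lies clearly beyond the usual scatter of such measurements.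

Compound 3, `COc1ccc2c(c1)c(C1=CCNCC1)cn2S(=O)(=O)c1cc2ccccc2cn1`, has not yet been measured. It keeps the core of compound 2 and changes only the ring attached to the sulfonyl sulfur: isoquinolin-3-yl in place of quinolin-7-yl on a sulfonyl sulfur. Compound 1 also carries isoquinolin-3-yl on its sulfonyl sulfur, but it differs from compound 3 elsewhere as well, so no single-change comparison is available, and any expectation rests on the two values alone.

Given that compound 2 is at 2 nM while compound 1, the only example with isoquinolin-3-yl, is at 12 nM, compound 3 is expected to land between them, with a modest weakening that may still fall within scatter, estimated as a 2.5-fold higher number from compound 2 to compound 3 (0.40 log units; beyond the scatter). The estimate for compound 3 is 5 nM, ranging from 1.5 nM to 18 nM.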

Compound 3, inhibition constant: 6 nM
Compound 3: the middle estimate sits 1.2-fold (0.08 log units) below what was measured; low and high end bracket the measured number.
By their numbers in this assay, from the lowest: compound 2; then compounds 3 and 1 (each within the scatter of the next).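

In this assay the ring on the sulfonyl sulfur can now be read with the rest of the molecule held fixed: isoquinolin-3-yl in place of quinolin-7-yl gives a 3.0-fold higher number from compound 2 to compound 3 (0.48 log units; beyond the scatter) and so counts as a modest but real change, even though the two rings have the same atoms, joined differently. With isoquinolin-3-yl on the sulfonyl sulfur, methoxy in place of hydrogen on an aromatic carbon gives a 2.0-fold lower number from compound 1 to compound 3 (0.30 log units; within the scatter) and thus shows no difference that can be told apart from repeat-to-repeat variation. No information at hand accounts for either step.

The compounds shown carry only these two rings on the sulfonyl sulfur and only hydrogen or methoxy on that aromatic carbon, so it stays open whether the ring swap would read the same way with hydrogen in place of methoxy. From the compounds shown here alone, it also stays open how a plain phenyl ring on the sulfonyl sulfur, or a chlorine or an ethoxy group in place of methoxy, would read.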